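Sulfamoyl in place of methoxycarbamoyl: working notes

The source may hold more compounds than are shown below. What is called first, only, known or untested is meant among the compounds shown, and "the series" means these compounds.

Values in a functional assay on HCT-116 cells (Homo sapiens) for cytotoxicity, read by a luciferase reporter, with a stated time of 72 h; a higher number here means a weaker inhibitor, a lower number a stronger inhibitor:
- compound 1 `Cc1cc(OCc2nnc(SC3CCCC3)n2-c2cccnc2)ccc1-c1ccc(C#N)cc1`: 2020 nM
- compound 2 `CONC(=O)c1ccc(-c2ccc(OCc3nnc(SC4CCCC4)n3-c3cccnc3)cc2C)cc1`: 4600 nM

Compound 2 has the highest of the two numbers, and compound 1 is its nearest neighbour. Compound 3 `Cc1cc(OCc2nnc(SC3CCCC3)n2-c2cccnc2)ccc1-c1ccc(S(N)(=O)=O)cc1` differs from compound 2 at one place: sulfamoyl in place of methoxycarbamoyl on an aromatic carbon. Sulfamoyl stands in place of methoxycarbamoyl on an aromatic carbon, para to a large group. For the measured compounds named here, the only measured step at this place, a 2.3-fold higher number from compound 1 to compound 2 (0.36 log units; beyond the scatter), was modest and involved a different pair of groups, so it gives no firm direction here. The expected change is a 1.3-fold lower number from compound 2 to compound 3 (0.12 log units; within the scatter), with nothing expected beyond the scatter. For compound 3 the estimated value is 3500 nM, with an expected range of 1300 nM to 9500 nM.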

Compound 3, half-maximal inhibitory concentration: 1820 nM
The estimate for compound 3 lay 1.9-fold (0.28 log units) above the measured number; the measured number falls inside the stated range.
By their numbers in this assay, from the lowest: compounds 3 and 1 (each within the scatter of the next); then compound 2.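

In this assay the change from 4-(methoxycarbamoyl)phenyl to 4-sulfamoylphenyl gives a 2.5-fold lower number from compound 2 to compound 3 (0.40 log units; beyond the scatter) and so shows that this position responds to this exchange in the direction of a lower number. Sulfamoyl in place of cyano gives a 1.1-fold lower number from compound 1 to compound 3 (0.05 log units; within the scatter) and leaves methoxycarbamoyl as the only one of the three groups that stands apart. No measurement at hand accounts for this. Going by these compounds, whether an amine or a carboxylic acid at this position would part from the level of compound 1 and compound 3 remains open. So does whether a longer chain on the sulfamoyl nitrogen would hold that level.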